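This account rests on a few compounds, and the source may have more. Where it says the series, first, only, none or still open, it means among the compounds named here.

Of the compounds shown here, two have so far been measured in a functional assay on MDA-MB-436 cells (Homo sapiens) for antiproliferative activity, read by MTT assay, with a stated time of 48 h; a lower number here means a stronger inhibitor, a higher number a weaker inhibitor. Compound 1 `C=CS(=O)(=O)N1CCN(c2ncnc3sc(-c4cccc5ncccc45)cc23)CC1` gives 25900 nM, and compound 2 `CN1CCN(c2ccc(-c3cc4c(N5CCN(S(=O)(=O)C6CC6)CC5)ncnc4s3)cc2)CC1` gives 10600 nM. Compound 2 therefore holds the lower of the two numbers, and its gap to compound 1 lies beyond the usual scatter, so it is the stronger inhibitor of the pair in this assay.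

Compound 3 `COc1ccc(NC(=O)N2CCN(c3ncnc4sc(-c5ccc(N6CCN(C)CC6)cc5)cc34)CC2)cc1` keeps the rest of compound 2 and changes one place: (4-methoxyphenyl)carbamoyl stands in place of cyclopropylsulfonyl on an amine nitrogen in a ring ((4-methoxyphenyl)carbamoyl in place of cyclopropylsulfonyl on an amine nitrogen in a ring). Within the data shown here, neither measured compound carries this carbamoyl group, and no measured pair shows what such a change does, so any forecast remains loose. The starting point is compound 2 at 10600 nM. A small move towards a stronger inhibitor is expected, though not one clearly beyond the scatter, with an estimated 1.8-fold lower number from compound 2 to compound 3 (0.25 log units; within the scatter). For compound 3 the expected value is 6000 nM, with an estimated range from 1500 nM to 25000 nM.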

Compound 3, half-maximal inhibitory concentration: 30100 nM
Compound 3: middle estimate off by 5.0-fold (0.70 log units), on the low side; the whole stated range lies below it.
By their numbers in this assay, from the lowest: compound 2; then compounds 1 and 3 (each within the scatter of the next).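

Among these compounds, on an amine nitrogen in a ring of a six-membered non-aromatic ring with 2 nitrogen, replacing cyclopropylsulfonyl with (4-methoxyphenyl)carbamoyl gives the first readable step at this position in this assay, with a 2.8-fold higher number from compound 2 to compound 3 (0.45 log units; beyond the scatter), which shows that the group carried here affects the read-out. The step is modest but beyond the scatter, and it runs towards a weaker inhibitor: in this pair, the entering group, with its six-membered aromatic ring and hydrogen-bond donor, does not improve on cyclopropylsulfonyl. Nothing measured on these compounds accounts for the step, so it stands as an observation only.

Since the whole group changes in one step, the compounds shown leave open whether the loss goes with the carbamoyl link, the aromatic ring or the methoxy group. On these data alone, a plain phenylcarbamoyl group or a small acetyl group on the same nitrogen would help to separate these parts, and whether any other group at this position could do better than cyclopropylsulfonyl also remains open.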